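Removing a methyl from the anilide ring of compound 3

The compounds below may be only part of what the source reports. "The series", "measured", "known", "first", "only" and "open" are said of these compounds alone.

Measured so far:
compound 1 `O=C(/C=C/C(=O)N1C/C(=C\c2ccccc2)C(=O)/C(=C/c2ccccc2)C1)Nc1ccc([N+](=O)[O-])cc1` gives 40000 nM
compound 2 `O=C(/C=C/C(=O)N1C/C(=C\c2ccc([N+](=O)[O-])cc2)C(=O)/C(=C/c2ccc([N+](=O)[O-])cc2)C1)Nc1ccc(Cl)c(Cl)c1` gives 1700 nM
compound 3 `Cc1ccc(NC(=O)/C=C/C(=O)N2C/C(=C\c3ccccc3)C(=O)/C(=C/c3ccccc3)C2)cc1` gives 5800 nM

In a functional assay on L1210 cells (Mus musculus) for cytotoxicity (a higher number here means a weaker inhibitor, a lower number a stronger inhibitor), compound 3 stands second highest of the three numbers, with compound 2 giving the lower value and compound 1 the higher one. Compound 4 `O=C(/C=C/C(=O)N1C/C(=C\c2ccccc2)C(=O)/C(=C/c2ccccc2)C1)Nc1ccccc1` differs from compound 3 by hydrogen in place of methyl on an aromatic carbon. Among the compounds with values here, only one measured step concerns this same ring position: a 6.9-fold lower number from compound 1 to compound 3 (0.84 log units; beyond the scatter), a change of one substituent for another, whereas here a substituent is simply taken away. Compound 2 differs in several places and does not bear directly on this step. A change of this kind, one carbon fewer, is expected to move the number little, so the estimated step of a 1.4-fold higher number from compound 3 to compound 4 (0.14 log units; within the scatter) stays near the scatter. Compound 4 is therefore expected to give about 8000 nM, within 3000 nM to 25000 nM.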

Compound 4, half-maximal inhibitory concentration: 3600 nM
For compound 4 the middle estimate is 2.2-fold (0.35 log units) above the measured one; the measured number falls inside the stated range.
By their numbers in this assay, from the lowest: compound 2; then compounds 4 and 3 (each within the scatter of the next); then compound 1.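

In this assay the step of a 1.6-fold lower number from compound 3 to compound 4 (0.21 log units; within the scatter) shows that the methyl adds nothing measurable here: compound 3 and compound 4 cannot be told apart. The step of an 11-fold lower number from compound 1 to compound 4 (1.05 log units; beyond the scatter) then shows that the nitro group of compound 1 is what stands apart at this position, since the ring without any substituent matches the methyl one rather than the nitro one. Nothing available explains this gap.

On these data alone, whether an amine or a carboxylic acid at this position would fall with compound 4 or with compound 1 stays open. So does the effect of a longer chain in place of the methyl.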